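Swapping the Amine on a Dithiocarbamate Chromone Series

The source may hold more compounds than are shown below. What is called first, only, known or untested is meant among the compounds shown, and "the series" means these compounds.

The study compares four compounds that share a dithiocarbamate-bearing core and differ in the amine on the thiocarbonyl carbon and in the substituent on the core. Compound 1 `O=c1c(Cl)c(CSC(=S)N2CCCCC2)oc2ccccc12` carries a piperidin-1-yl group; in a functional assay on HEp-2 cells (Homo sapiens) for antiproliferative activity, read by MTT assay, with a stated time of 72 h (on this read-out lower numbers stand for stronger inhibition and higher numbers for weaker inhibition), compound 1 gives 940 nM. Compound 2 `CC(C)N(C(=S)SCc1oc2ccccc2c(=O)c1Cl)C(C)C` carries a diisopropylamino group instead, and in this assay compound 2 gives 20000 nM. The change between them, (piperidin-1-yl in place of diisopropylamino on a thiocarbonyl carbon), produced a 21-fold lower number from compound 2 to compound 1 (1.33 log units; beyond the scatter). Compound 3 `COc1ccc2oc(CSC(=S)N(C(C)C)C(C)C)cc(=O)c2c1` keeps the diisopropylamino group on a different core; in this assay compound 3 gives 7600 nM. The difference between the core of compound 3 and the core of compound 2 is not broken down here.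

Compound 4 `COc1ccc2oc(CSC(=S)N3CCCCC3)cc(=O)c2c1` has not yet been measured. It differs from compound 3 by piperidin-1-yl in place of diisopropylamino on a thiocarbonyl carbon, the same change that separates compound 2 from compound 1, made at an identical place. Because the earlier instance gave a 21-fold lower number from compound 2 to compound 1 (1.33 log units; beyond the scatter), a step of similar direction is expected, estimated as a 13-fold lower number from compound 3 to compound 4 (1.10 log units; beyond the scatter), though a single precedent warrants caution. Compound 4 is therefore expected to give 600 nM in this assay, within 150 nM to 2500 nM.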

Compound 4, half-maximal inhibitory concentration: 1500 nM
Compound 4: the middle estimate sits 2.5-fold (0.40 log units) below what was measured; the measured number falls inside the stated range.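

In this assay, piperidin-1-yl in place of diisopropylamino again goes with a lower number on the second core, a 5.1-fold lower number from compound 3 to compound 4 (0.70 log units; beyond the scatter), so the direction of the change carried over in the two pairs shown. The size of the step did not carry over, and the core therefore matters to how much this swap changes the number: the same change on two cores in this assay, a 21-fold lower number (1.33 log units; beyond the scatter) from compound 2 to compound 1 and a 5.1-fold lower number (0.70 log units; beyond the scatter) from compound 3 to compound 4, 4.2-fold (0.62 log units) apart, beyond the scatter of two such steps. This does not show which feature of the two cores goes with the smaller step, since they differ in a way not broken down here, and two pairs give no rule for any further core.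

The compounds shown leave open whether other cyclic amines on a thiocarbonyl carbon, such as pyrrolidin-1-yl or morpholin-4-yl, would follow the same direction as piperidin-1-yl. They also leave open whether a core carrying only the chlorine or only the methoxy group would give a step closer to the larger or to the smaller one.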